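The source may report more compounds than this note shows. Statements on the series, on what has been measured and on what is new or still open speak of the compounds shown alone.

Working notes on the series. Compound 1 `C[C@H](Nc1ncnc2[nH]cnc12)c1nn(-c2cccnc2)c2cc(F)ccc12` is the reference point. In a functional assay on Bel-7402 cells (Homo sapiens) for inhibition, read by sulforhodamine B assay, with a stated time of 72 h, tested at 10 uM (a lower number here means less inhibition, a higher number more inhibition at the concentration tested (going by the name of the read-out)), compound 1 gives 8%, the lowest of the two numbers in hand. Going by the values given here, the only other measured compound, compound 2 `C[C@H](Nc1ncnc2[nH]cnc12)c1nn(-c2ccncc2)c2cc(F)ccc12`, gives in this assay a value of 16%. Among the compounds with values here, the single measured step, a number 8 percentage points higher from compound 1 to compound 2 (within the scatter), concerns pyridin-4-yl in place of pyridin-3-yl on an aromatic nitrogen and lies within the scatter, so compound 1 and compound 2 cannot be ordered against one another.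

The next compound, compound 3 `C[C@H](Nc1nc(N)nc2[nH]cnc12)c1nn(-c2cccnc2)c2cc(F)ccc12`, has not yet been measured in this assay. Against compound 1 it differs at one place: amino in place of hydrogen on an aromatic carbon. Within the data shown here, no measured step touches this part of the shared core; the one step in hand, a number 8 percentage points higher from compound 1 to compound 2 (within the scatter), sits elsewhere and was within the scatter in any case. The data therefore give no ground for a shift beyond the scatter in either direction in this assay, and both measured numbers are low. The estimate for compound 3 is accordingly a step of a number 2 percentage points higher from compound 1 to compound 3 (within the scatter), an expected value of 10% within a range from 0% to 30%.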

Compound 3, a percentage reported as inhibition, at one concentration (the size of the read-out at that concentration, not a potency): -5%
Beside the measured number, compound 3's estimate is 15 percentage points above it; measured number outside the range, below it.
By their numbers in this assay, from the lowest: compound 3; then compounds 1 and 2 (each within the scatter of the next).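

Going by these compounds alone, this is the first step to touch the aromatic carbon between two ring nitrogen atoms, and in this assay amino in place of hydrogen gives a number 13 percentage points lower from compound 1 to compound 3 (beyond the scatter). Within the data shown here, this place on the shared core can therefore move the number beyond the scatter, which the one earlier step, at the pyridinyl group on the aromatic nitrogen, did not do. The move is downward from an already low starting point, so on this single pair amino adds no inhibition at the concentration tested, and nothing in hand accounts for the drop.

As far as these compounds go, it remains open whether the step belongs to amino itself or to any replacement of hydrogen at this carbon, which a methyl group or a chlorine atom in the same place would help to separate. Also open, from the compounds shown here alone, is whether amino carries a similar step when pyridin-4-yl sits on the aromatic nitrogen, as in compound 2, and whether any group at this carbon can raise the number rather than lower it.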